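Swap of a chain substituent on the shared core

The source may report more compounds than this note shows. Statements on the series, on what has been measured and on what is new or still open speak of the compounds shown alone.

Measured so far in a functional assay on HeLa cells (Homo sapiens) for cytotoxicity, read by neutral red uptake, with a stated time of 3 days; a lower number here means a stronger inhibitor, a higher number a weaker inhibitor:
compound 1 `Nc1ccc(-c2cc(=O)c3c(N)c(F)c(Br)c(F)c3o2)cc1F` gives > 100000 nM
compound 2 `CN(C)CC(=O)OCc1c(F)c(N)c2c(=O)cc(-c3ccc(N)c(F)c3)oc2c1F` gives 9200 nM
compound 3 `CCCCCCOCc1c(F)c(N)c2c(=O)cc(-c3ccc(N)c(F)c3)oc2c1F` gives > 100000 nM

In this assay compound 3 sits at > 100000 nM, which is a limit of the assay and not a number. For compound 1 the value > 100000 nM is likewise a limit. Among the compounds with values here, compound 2 is the only member with a measured number, 9200 nM. Within the data shown here, the one readable step is an at least 10-fold higher number from compound 2 to compound 3 (1.03 log units; beyond the scatter); the step that the two limits leave unreadable from compound 1 to compound 3 cannot be sized, and an at least 10-fold lower number from compound 1 to compound 2 (1.03 log units; beyond the scatter) is large. Two of the three values sit at the limit of > 100000 nM in this assay, at which 2 of the 3 values shown sit.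

Compound 4 `NCc1c(F)c(N)c2c(=O)cc(-c3ccc(N)c(F)c3)oc2c1F` differs from compound 3 by amino in place of hexyloxy on a saturated chain carbon bound to an aromatic carbon. Among the measured compounds shown here, the step of an at least 10-fold higher number from compound 2 to compound 3 (1.03 log units; beyond the scatter) shows that the hexyl group on that oxygen raises the number markedly relative to the aminoacyl ester; removing the hexyloxy group altogether is expected to move the number back down, but no measured step tests the amino group itself. The step from compound 3 to compound 4 in this assay is therefore expected to be an at least 4.0-fold lower number from compound 3 to compound 4 (0.60 log units; beyond the scatter), with considerable uncertainty. For compound 4 the estimate in this assay is 25000 nM, within 6000 nM to 100000 nM.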

Compound 4, half-maximal inhibitory concentration: 8800 nM
Beside the measured number, compound 4's estimate is 2.8-fold (0.45 log units) above it; low and high end bracket the measured number.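

In this assay, the ester of compound 2 is not required for a measured number at this place: aminomethyl and the ester-bearing chain stand level, with a 1.0-fold lower number from compound 2 to compound 4 (0.02 log units; within the scatter). Amino in place of hexyloxy gives an at least 11-fold lower number from compound 3 to compound 4 (1.05 log units; beyond the scatter), and aminomethyl in place of bromo gives an at least 11-fold lower number from compound 1 to compound 4 (1.05 log units; beyond the scatter), so the two compounds with a measured number both carry a nitrogen in the chain at this place, while the other two do not. Both of these steps start from a limit of the assay and fix only a minimum size: the limit of > 100000 nM in this assay, at which 2 of the 4 values shown sit.

The step from compound 1 to compound 3 cannot be read. Going by these compounds, whether that nitrogen matters remains open, and a hydroxymethyl group or a longer aminoalkyl chain on the shared core would test it.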